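Lipophilicity of three measured oxime salts and one expected

The compounds below may be only part of what the source reports. "The series", "measured", "known", "first", "only" and "open" are said of these compounds alone.

Compound 1 `C#CC(C)OC[n+]1ccn(C)c1/C=N/O`: -2.14
Compound 2 `C#CC(CCC)OC[n+]1ccn(C)c1/C=N/O`: -1.1
Compound 3 `C#CCC(C)OC[n+]1ccn(C)c1/C=N/O`: -2.1

In a physicochemical assay for lipophilicity (on this read-out higher numbers stand for higher lipophilicity and lower numbers for lower lipophilicity), compound 1 gives -2.14 and compound 2 gives -1.1. The change between them is ethyl in place of hydrogen on a saturated chain carbon, two bonds along the chain from an oxygen on a saturated carbon and a triple-bonded carbon and it made a step of a number 1.04 log units higher from compound 1 to compound 2 (beyond the scatter). Compound 3 differs from compound 1 by propargyl in place of ethynyl on a saturated chain carbon bound to an oxygen on a saturated carbon and a saturated chain carbon, a difference of the cores that gave a number 0.04 log units higher from compound 1 to compound 3 (within the scatter). Compound 4 `C#CCC(CCC)OC[n+]1ccn(C)c1/C=N/O` is unmeasured; it differs from compound 3 by ethyl in place of hydrogen on a saturated chain carbon, two bonds along the chain from an oxygen on a saturated carbon, the same kind of change, though here the place is described only as two bonds along the chain from an oxygen on a saturated carbon, without the triple-bonded carbon named for compound 1. Because compound 1 to compound 2 showed a number 1.04 log units higher from compound 1 to compound 2 (beyond the scatter), a step of a number 1.04 log units higher from compound 3 to compound 4 (beyond the scatter) is expected in this assay. Compound 4 is therefore estimated at -1.06, between -1.45 and -0.7.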

Compound 4, distribution coefficient: -1.17
For compound 4 the middle estimate is 0.11 log units above the measured one, and the stated range covers the measured number.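

In this assay, the ethyl in place of hydrogen gave a number 0.93 log units higher from compound 3 to compound 4 (beyond the scatter), a step in the same direction as a number 1.04 log units higher from compound 1 to compound 2 (beyond the scatter), and both lie beyond the scatter, so the change carried from the ethynyl core to the propargyl core in this one pair. The core difference read with ethyl present gave a number 0.07 log units lower from compound 2 to compound 4 (within the scatter), which stays within the scatter, as it did without ethyl, though two cores cannot show that the step holds across the series. Nothing available explains the size of either step.

The compounds shown leave open how this assay would respond to a longer chain or an amine in place of the ethyl. They also leave open whether the step would persist on a core carrying neither ethynyl nor propargyl.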